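The compounds below may be only part of what the source reports. "The series", "measured", "known", "first", "only" and "open" are said of these compounds alone.

Measured compounds:
Compound 1 `CCCCS(=O)(=O)n1ccc2c(N(C)C)cccc21` — in an assay on isolated protein for displacement of a labelled ligand from 5-hydroxytryptamine receptor 6 (Homo sapiens), read by scintillation counting, with a stated time of 1 h (a higher number here means a weaker inhibitor, a lower number a stronger inhibitor), compound 1 gives 49900 nM.
Compound 2 `CN(C)c1cccc2c1ccn2S(=O)(=O)N1CCCCC1` — in this assay compound 2 gives 39100 nM.

Among the measured compounds shown here, compound 2 stands at the lower of the two numbers, but its only neighbour is compound 1, and the step of a 1.3-fold lower number from compound 1 to compound 2 (0.11 log units; within the scatter) lies within the scatter, so the two cannot be told apart on these data. Compound 3 `CN(C)c1cccc2c1ccn2S(=O)(=O)C1CCCCC1` has not yet been measured. It differs from compound 2 in one place: cyclohexyl in place of piperidin-1-yl on a sulfonyl sulfur. For the measured compounds named here, the one measured step that bears on a change at this sulfonyl sulfur is the one from compound 1 to compound 2, which exchanged a chain for a ring there and moved the number by a 1.3-fold lower number from compound 1 to compound 2 (0.11 log units; within the scatter), no more than the scatter. On that basis no step beyond the scatter is expected in this assay for the new ring either, in neither direction, so the step of a 1.1-fold lower number from compound 2 to compound 3 (0.05 log units; within the scatter) is expected to stay small. Compound 3 is therefore estimated at 35000 nM, with a range from 12000 nM to 100000 nM.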

Compound 3, inhibition constant: 4890 nM
Beside the measured number, compound 3's estimate is 7.2-fold (0.85 log units) above it; measured number below the stated range.
By their numbers in this assay, from the lowest: compound 3; then compounds 2 and 1 (each within the scatter of the next).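

At this sulfonyl sulfur, this assay does respond to the group attached, which compounds 1 and 2 could not show: the step of an 8.0-fold lower number from compound 2 to compound 3 (0.90 log units; beyond the scatter) is beyond the scatter, although the change only puts a ring carbon where piperidin-1-yl has its ring nitrogen. Having a six-membered ring there is not enough on its own, since the step of a 10-fold lower number from compound 1 to compound 3 (1.01 log units; beyond the scatter) is large for cyclohexyl in place of butyl, while piperidin-1-yl in place of butyl stays within the scatter.

Nothing here explains why the all-carbon ring gives the lower number. From the compounds shown here alone, it also remains open whether the trend continues with other groups on this sulfur, such as a cyclopentyl ring, a phenyl ring or a morpholin-4-yl ring.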